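The compounds below may be only part of what the source reports. "The series", "measured", "known", "first", "only" and "open" are said of these compounds alone.

In a functional assay on DU-145 cells (Homo sapiens) for cytotoxicity, read by sulforhodamine B assay, with a stated time of 48 h (on this read-out higher numbers stand for weaker inhibition and lower numbers for stronger inhibition), compound 1 (`COc1ccc(C2=NO[C@]3(C2)C(=O)O[C@@H]2[C@H]3CC[C@H](C)[C@]3(O)C=CC(=O)[C@@]23C)cc1`) gives 20000 nM and compound 2 (`COc1ccc(C2=NO[C@]3(C2)C(=O)O[C@@H]2[C@H]3CC[C@H](C)[C@]3(O)C=CC(=O)[C@@]23C)cc1OC`) gives 84000 nM as the higher of the two numbers, which makes it the weaker of the pair. Compound 3 (`C[C@H]1CC[C@@H]2[C@@H](OC(=O)[C@]23CC(c2cccc([N+](=O)[O-])c2)=NO3)[C@]2(C)C(=O)C=C[C@@]12O`) is still unmeasured and carries 3-nitrophenyl in place of 3,4-dimethoxyphenyl on a carbon with a double bond to nitrogen. Among the measured compounds shown here, the one measured step that bears on this is a 4.2-fold higher number from compound 1 to compound 2 (0.62 log units; beyond the scatter) with methoxy in place of hydrogen on an aromatic carbon, modest but beyond the scatter. For the measured compounds named here, compound 3 has neither methoxy group, so a lower number seems likely, although no measured compound carries a nitro group to test this. In this assay the estimated step is a 2.4-fold lower number from compound 2 to compound 3 (0.38 log units; beyond the scatter) as a modest expected drop. Compound 3 is expected at about 35000 nM (range 10000 nM to 100000 nM).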

Compound 3, half-maximal inhibitory concentration: 51000 nM
Beside the measured number, compound 3's estimate is 1.5-fold (0.16 log units) below it; low and high end bracket the measured number.
By their numbers in this assay, from the lowest: compound 1; then compounds 3 and 2 (each within the scatter of the next).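

In this assay, the step of a 1.6-fold lower number from compound 2 to compound 3 (0.22 log units; within the scatter) shows that 3-nitrophenyl and 3,4-dimethoxyphenyl cannot be told apart at this position, even though the two groups share no substituent. The step of a 2.6-fold higher number from compound 1 to compound 3 (0.41 log units; beyond the scatter) shows that 3-nitrophenyl, like 3,4-dimethoxyphenyl, stays apart from the 4-methoxyphenyl of compound 1, so a ring without any methoxy group does not return to the number of compound 1. Nothing measured on these groups explains this pattern.

On these data alone, how an amine or a carboxylic acid on the phenyl ring would fare at this position remains open. So does the result for plain unsubstituted phenyl, which would show how any of these three rings compares with a ring that carries no added group.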